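The source may hold more compounds than are shown below. What is called first, only, known or untested is meant among the compounds shown, and "the series" means these compounds.

Values in a functional assay on BXPC-3 cells (Homo sapiens) for antiproliferative activity, read by MTT assay, with a stated time of 24 h; on this read-out lower numbers stand for stronger inhibition and higher numbers for weaker inhibition:
- compound 1 `CCn1c(C(=O)NCCO)ccc1C(CC)(CC)c1ccc(OCS(=O)(=O)c2ccccc2)c(C)c1`: 19900 nM
- compound 2 `CCn1c(C(=O)NC(C)(C)CO)ccc1C(CC)(CC)c1ccc(OCS(=O)(=O)c2ccccc2)c(C)c1`: 18300 nM
- compound 3 `CCn1c(C(=O)N[C@@H](CO)C(C)C)ccc1C(CC)(CC)c1ccc(OCS(=O)(=O)c2ccccc2)c(C)c1`: 13200 nM
- compound 4 `CCn1c(C(=O)N[C@H](C)C(=O)O)ccc1C(CC)(CC)c1ccc(OCS(=O)(=O)c2ccccc2)c(C)c1`: not yet measured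

The three measured compounds cannot be ranked in this assay. Compound 3, at 13200 nM, lies within the scatter of both compound 1 and compound 2.

The next change is 1-carboxyethyl in place of 1-(hydroxymethyl)-2-methylpropyl on an amide-type nitrogen. In words, 1-carboxyethyl enters in place of 1-(hydroxymethyl)-2-methylpropyl on an amide-type nitrogen, while the rest of the structure stays the same.

Going by the values given here, three measured steps bear on this position: a 1.1-fold lower number from compound 1 to compound 2 (0.04 log units; within the scatter), a 1.5-fold lower number from compound 1 to compound 3 (0.18 log units; within the scatter) and a 1.4-fold lower number from compound 2 to compound 3 (0.14 log units; within the scatter). Among the compounds with values here, all three are small and lie within the scatter, and no compound among the three goes against this. They show that exchanging these hydroxyl-bearing substituents on the amide-type nitrogen has not moved the read-out measurably. However, none of the measured compounds carries 1-carboxyethyl, so these steps support the new group only indirectly. A large step cannot be ruled out, and the range is kept wide, especially towards higher numbers.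

No step beyond the scatter is expected, with the direction, if any, tentatively towards a higher number. The expected step is a 1.5-fold higher number from compound 3 to compound 4 (0.18 log units; within the scatter). For compound 4 the estimated value is 20000 nM, with an expected range of 9000 nM to 50000 nM.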

Compound 4, half-maximal inhibitory concentration: 20100 nM
The estimate for compound 4 lay 1.0-fold (0.00 log units) below the measured number; the range from low to high includes it.
By their numbers in this assay, from the lowest: compounds 3, 2, 1 and 4 (each within the scatter of the next).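

In this assay, a carboxylic acid on the amide-type nitrogen now stands alongside the hydroxyl-bearing substituents, and all three new comparisons lie within the scatter: a 1.5-fold higher number from compound 3 to compound 4 (0.18 log units; within the scatter) and a 1.1-fold higher number from compound 2 to compound 4 (0.04 log units; within the scatter) and also a 1.0-fold higher number from compound 1 to compound 4 (0.00 log units; within the scatter). The earlier compounds shown here covered only hydroxyl-bearing substituents at this place, whereas 1-carboxyethyl replaces the hydroxyl with a carboxylic acid and still leaves the read-out without a measurable move, with none of the four compounds going against this. No supporting measurement accompanies this result.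

Still open, on these data alone, is whether any substituent on this amide-type nitrogen can move the read-out beyond the scatter, for example an amine such as 1-aminoethyl, a longer chain ending in a carboxylic acid, or a substituent carrying a ring. The compounds shown also leave open whether the opposite stereocentre of 1-carboxyethyl would read the same, and whether changes elsewhere on the shared core, such as to the phenylsulfonyl group, would do more than changes at this nitrogen.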